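Hydroxamic acids on a piperidine sulfonyl scaffold: anilino to chlorophenyl

This account rests on a few compounds, and the source may have more. Where it says the series, first, only, none or still open, it means among the compounds named here.

Measured so far:
compound 1, `O=C(CCCC1CCN(S(=O)(=O)Nc2ccccc2)CC1)NO`: 2000 nM
compound 2, `COc1ccc(S(=O)(=O)N2CCC(CCCC(=O)NO)CC2)cc1OC`: "not determined" (no result reported)

Going by the values given here, compound 1 is the only member of this set with a number in a functional assay on HCT-116 cells (Homo sapiens) for inhibition, read by resazurin assay, with a stated time of 5 days; on this read-out higher numbers stand for weaker inhibition of growth and lower numbers for stronger inhibition of growth; compound 2 carries no result there, so nothing can be said of how the two compare. Compound 3, `O=C(CCCC1CCN(S(=O)(=O)c2ccccc2Cl)CC1)NO`, is the unmeasured partner. It keeps the whole of compound 1 apart from one change: 2-chlorophenyl in place of anilino on a sulfonyl sulfur. Among the compounds with values here, no step between two measured compounds is available to anchor this change, so the expectation rests on compound 1 alone. Within the data shown here, for compound 3 in this assay a step of a 1.3-fold higher number from compound 1 to compound 3 (0.10 log units; within the scatter) is expected, which is no more than the usual scatter, since there is no measured pair that argues for a shift in either direction. Compound 3 is therefore estimated at 2500 nM, with a range from 700 nM to 9000 nM.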

Compound 3, concentration for 50% growth inhibition: 2800 nM
Estimate against measurement, compound 3: 1.1-fold (0.05 log units) below; the range from low to high includes it.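

In this assay, going by these compounds alone, 2-chlorophenyl in place of anilino on a sulfonyl sulfur gives a 1.4-fold higher number from compound 1 to compound 3 (0.15 log units; within the scatter), the first step in this set that can be read at this position. The exchange removes the hydrogen-bond donor of anilino and brings in a chlorine, yet the two compounds cannot be told apart on this read-out, so for this pair the anilino donor is not required to keep growth inhibition at the level of compound 1. Nothing in the data shown explains why the two compounds read alike.

The compounds shown leave open how a plain phenyl, without the chlorine, or a carboxylic acid or an amine on the aromatic ring would read at this position. They also leave open whether a longer chain ahead of the hydroxamic acid would move the value by more than this exchange did.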